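This account rests on a few compounds, and the source may have more. Where it says the series, first, only, none or still open, it means among the compounds named here.

Compound 1 `CN1CCC(NC(=O)c2ccc(Nc3ncc([N+](=O)[O-])c(NC4CCCC4)n3)cc2)CC1` gives 15600 nM in a functional assay on HCT-8 cells (Homo sapiens) for cytotoxicity, read by MTT assay, with a stated time of 48 h; on this read-out higher numbers stand for weaker inhibition and lower numbers for stronger inhibition. Compound 2 `COc1cc(C(=O)NC2CCN(C)CC2)ccc1Nc1ncc(Br)c(NC2CCCC2)n1` gives 12000 nM in this assay, and the two numbers lie within the usual scatter of each other, so neither compound can be called the more potent. Compound 3 `CN1CCC(NC(=O)c2ccc(Nc3ncc(Cl)c(NC4CCCC4)n3)cc2)CC1` is not yet measured. It differs from compound 1 by chloro in place of nitro on an aromatic carbon. For the measured compounds named here, no measured pair shows this exact change, so the expected step is uncertain; a step of a 1.2-fold lower number from compound 1 to compound 3 (0.08 log units; within the scatter) is estimated, meaning none beyond the scatter. Compound 3 is expected to give about 13000 nM in this assay, with a range from 5000 nM to 35000 nM.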

Compound 3, half-maximal inhibitory concentration: 4600 nM
The estimate for compound 3 lay 2.8-fold (0.45 log units) above the measured number, outside the stated range (below it).
By their numbers in this assay, from the lowest: compound 3; then compounds 2 and 1 (each within the scatter of the next).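

In this assay, a 3.4-fold lower number from compound 1 to compound 3 (0.53 log units; beyond the scatter) follows when chloro replaces nitro on this aromatic carbon, ortho to a cyclopentylamino group. This step lies beyond the scatter, so the group at this position does affect the read-out, even with the rest of compound 1 unchanged. No measurement at hand explains the step. Still open, going by these compounds, is how a nitrile, a trifluoromethyl group or an amine would fare at this position. Also open, on these data alone, is whether chloro in place of nitro would give a similar step on a different core.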